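Phenyl for furan-3-yl on the shared core: cytotoxicity notes

The compounds below may be only part of what the source reports. "The series", "measured", "known", "first", "only" and "open" are said of these compounds alone.

Compound 3 `O=C(O)/C=C/c1ccc(NC(=O)C2(NC(=O)c3ccc4c(c3)nc(-c3ccoc3)n4C3CCCCC3)CCC2)cc1` stands at a limit in an ADME assay on Huh-7 cells (Homo sapiens) for cytotoxicity; a lower number here means that less compound is tolerated, a higher number that more compound is tolerated: compound 3 gives > 10 uM, a limit of the assay rather than a number. Compound 1 `O=C(O)/C=C/c1ccc(NC(=O)C2(NC(=O)c3ccc4c(c3)nc(-c3cccs3)n4C3CCCCC3)CCC2)cc1` likewise gives a limit, > 10 uM. Compound 2 `O=C(O)/C=C/c1ccc(NC(=O)C2(NC(=O)c3ccc4c(c3)nc(-c3ccco3)n4C3CCCCC3)CCC2)cc1` also gives a limit, > 10 uM. Accordingly a step that the two limits leave unreadable from compound 1 to compound 2, a step that the two limits leave unreadable from compound 1 to compound 3 and a step that the two limits leave unreadable from compound 2 to compound 3 stay unreadable, because of the limit of > 10 uM in this assay, at which 3 of the 3 values shown sit. Compound 4 `O=C(O)/C=C/c1ccc(NC(=O)C2(NC(=O)c3ccc4c(c3)nc(-c3ccccc3)n4C3CCCCC3)CCC2)cc1` carries phenyl in place of furan-3-yl on an aromatic carbon. For the measured compounds named here, no measured step bears readably on this change; all that is known is that the three compounds with a five-membered ring at this place sit at the same limit. The expected step for compound 4 is therefore none beyond the scatter, a step that the limit leaves unreadable from compound 3 to compound 4, most likely ending again in a limit. The estimate for compound 4 in this assay is 20 uM, with a range from 8 uM to 60 uM.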

Compound 4, half-maximal toxic concentration: > 10 uM
Compound 4: a limit, no number; the forecaster's own chance of this, stated with the estimate: 85%; the middle value is on the limit's open side.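

No step to compound 4 from compound 1, compound 2 or compound 3 can be read in this assay: the limit of > 10 uM in this assay, at which 4 of the 4 values shown sit.

The compounds shown leave open whether thiophen-2-yl, furan-2-yl, furan-3-yl and phenyl at this place differ at all in this assay.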